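A few compounds are considered here, and "the series" means these few. Any claim that something is new, unique, unknown or untested is made for them only; others in the source may bear on it.

Two compounds of this set have a measured number. Compound 1 `CC(=O)c1ccc(OCCCN2CC[C@H](NC(=O)[C@@H](N)CO)C2)cc1` carries a serinamide on the pyrrolidine; in an assay on isolated protein for binding affinity to histamine H2 receptor (Homo sapiens) (a higher number here means a weaker inhibitor, a lower number a stronger inhibitor), compound 1 gives 22000 nM. Compound 2 `COc1ccc(S(=O)(=O)N[C@H]2CCN(CCCOc3ccc(C(=O)C4CC4)cc3)C2)cc1` carries an arylsulfonamide in that position instead; in this assay compound 2 gives 1000 nM. Compound 2 thus stands at the lower of the two numbers, and the gap to compound 1 lies beyond the usual scatter. From compound 2 the step to compound 3 `Cc1ccccc1S(=O)(=O)N[C@H]1CCN(CCCOc2ccc(C(=O)C3CC3)cc2)C1` is 2-methylphenyl in place of 4-methoxyphenyl on a sulfonyl sulfur, a change confined to the aryl group on the sulfonyl sulfur while the rest of the molecule is unchanged. Among the measured compounds shown here, no measured pair in this set isolates such a change, so the direction of the step is open. The expected step is small, a 1.5-fold higher number from compound 2 to compound 3 (0.18 log units; within the scatter), most likely within the scatter. Compound 3 is estimated to give 1500 nM, within a range from 400 nM to 6000 nM.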

Compound 3, inhibition constant: 2200 nM
Estimate against measurement, compound 3: 1.5-fold (0.17 log units) below; measured number inside the range.
By their numbers in this assay, from the lowest: compound 2; then compound 3; then compound 1.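

The aryl group on the sulfonyl sulfur proves sensitive to substitution: in this assay, 2-methylphenyl in place of 4-methoxyphenyl gives a 2.2-fold higher number from compound 2 to compound 3 (0.34 log units; beyond the scatter), a modest step but one beyond the scatter. Among the compounds shown here, this is the first pair in the set that differs in one place, so the direction of this change can now be read, and 4-methoxyphenyl holds the lower number. Nothing at hand accounts for the step.

On these data alone, it remains open whether a plain phenyl, a 4-methylphenyl or a 2-methoxyphenyl would separate the effect of the substituent from that of its placement on the ring. Also open, as far as these compounds go, is whether an amine or a carboxylic acid on this aryl group would bring the number lower or raise it further.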